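Oxadiazole series: adding a carboxypentyl chain to compound 1

This account rests on a few compounds, and the source may have more. Where it says the series, first, only, none or still open, it means among the compounds named here.

Measured so far:
compound 1 `Cc1ccccc1-c1noc(-c2ccc(C3CCCCC3)cc2)n1`: 266 nM
compound 2 `Cc1cc(CCC(=O)O)ccc1-c1noc(-c2ccc(OC(C)C)c(Br)c2)n1`: 43 nM

In a functional assay on CHO cells for agonist activity at sphingosine 1-phosphate receptor 5 (Homo sapiens), read by GTPgammaS binding (a higher number here means that more compound is needed for the effect, a lower number that less compound is needed), compound 1 gives 266 nM, the highest of the two numbers. Compound 2, which carries a carboxylic acid chain on its methyl-bearing ring, gives 43 nM in this assay, a lower number than compound 1 by a margin beyond the scatter.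

Compound 3 `Cc1cc(CCCCCC(=O)O)ccc1-c1noc(-c2ccc(C3CCCCC3)cc2)n1` is not yet measured. It differs from compound 1 in one place: 5-carboxypentyl in place of hydrogen on an aromatic carbon, meta to a methyl group and para to a large group.

Within the data shown here, no measured pair isolates this change. Still, compound 2 with its acid chain gives 43 nM, and on that basis the step from compound 1 to compound 3 is expected to lower the number beyond the scatter, an 8.9-fold lower number from compound 1 to compound 3 (0.95 log units; beyond the scatter). Compound 3 is therefore estimated at 30 nM in this assay, with a range from 8 nM to 120 nM.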

Compound 3, half-maximal effective concentration: 1080 nM
The estimate for compound 3 lay 36-fold (1.56 log units) below the measured number; the measured number lies above the stated range.
By their numbers in this assay, from the lowest: compound 2; then compound 1; then compound 3.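

In this assay, 5-carboxypentyl in place of hydrogen on the aromatic carbon meta to the methyl group and para to a large group gives a 4.1-fold higher number from compound 1 to compound 3 (0.61 log units; beyond the scatter), a modest step. Among these compounds, this is the only single-place reading at this position, and it shows that on the core of compound 1 this chain raises the number, while compound 2, which also carries an acid chain, differs from compound 3 in more than one place and cannot be read against it. Nothing on hand accounts for the rise.

From the compounds shown here alone, it remains open whether the rise follows the length of the chain or the carboxylic acid at its end. A 2-carboxyethyl chain, a plain pentyl chain or an amine-ending chain at this position on the core of compound 1 would separate these.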